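The source may report more compounds than this note shows. Statements on the series, on what has been measured and on what is new or still open speak of the compounds shown alone.

In a functional assay on MDA-MB-231 cells (Homo sapiens), read by microscopy and transwell migration, with a stated time of 24 h (a lower number here means a stronger inhibitor, a higher number a weaker inhibitor), the measured compounds are:
compound 1 `CCn1c(-c2ccccc2)cs/c1=N\C(=O)c1ccccc1` gives 51.5 nM
compound 2 `CCCn1c(-c2ccccc2)cs/c1=N\C(=O)c1ccccc1` gives 657 nM
compound 3 `CCN(C(=O)c1ccccc1)c1nc(-c2ccccc2)cs1` gives 533 nM

Compound 2 differs from compound 1 by methyl in place of hydrogen on a saturated chain carbon, two bonds along the chain from an aromatic nitrogen and this single change made the step of a 13-fold higher number from compound 1 to compound 2 (1.11 log units; beyond the scatter). Compound 3 has the same atoms as compound 1 joined differently; how the two cores differ is not broken down here. The values of compound 3 and compound 2 lie within the scatter of each other.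

Compound 4 `CCCN(C(=O)c1ccccc1)c1nc(-c2ccccc2)cs1` has not been measured. It differs from compound 3 by methyl in place of hydrogen on a saturated chain carbon, two bonds along the chain from an amide-type nitrogen. This is the same kind of change as that from compound 1 to compound 2, but the place differs: there the added methyl sat two bonds from an aromatic nitrogen, here it sits two bonds from an amide-type nitrogen. For compound 4 in this assay a rise in the number is expected because a 13-fold higher number from compound 1 to compound 2 (1.11 log units; beyond the scatter) was large, but a smaller one, since the surroundings are not the same: the step expected is a 3.8-fold higher number from compound 3 to compound 4 (0.57 log units; beyond the scatter). Compound 4 is estimated at 2000 nM, between 600 nM and 8000 nM.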

Compound 4, half-maximal inhibitory concentration: 77 nM
Beside the measured number, compound 4's estimate is 26-fold (1.41 log units) above it; measured number below the stated range.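

In this assay the added methyl gave a 6.9-fold lower number from compound 3 to compound 4 (0.84 log units; beyond the scatter), which runs in the opposite direction to the earlier step. Going by these compounds alone, the same ethyl to propyl change therefore cannot be carried from one core to the other, as the two steps show: the same change on two cores in this assay, a 13-fold higher number (1.11 log units; beyond the scatter) from compound 1 to compound 2 and a 6.9-fold lower number (0.84 log units; beyond the scatter) from compound 3 to compound 4, 88-fold (1.95 log units) apart, beyond the scatter of two such steps This shows that the outcome of this change differs between these two cores, but with only two pairs it does not show why, or how any other change would behave on them.

Going by these compounds, it remains open whether a longer chain such as butyl, or a shorter one such as methyl, on the nitrogen would also pull the two cores apart.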